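The compounds below may be only part of what the source reports. "The series", "measured", "known", "first", "only" and "open" are said of these compounds alone.

Measured compounds in an assay on MCF7 cells for inhibition of Serine-protein kinase ATM (Homo sapiens), read by immunofluorescence, with a stated time of 1 h; a higher number here means a weaker inhibitor, a lower number a stronger inhibitor:
compound 1 `COc1cc2ncnc(-n3nc(-c4ccccn4)nc3N)c2cc1OCCCN1CC(C)OC(C)C1`, 1600 nM
compound 2 `COCCOc1cc2c(-n3nc(-c4ccccn4)nc3N)ncnc2cc1OC`, 1200 nM
compound 3 `COc1cc2ncnc(-n3nc(-c4ccccn4)nc3N)c2cc1OCCCCNC(=O)OC(C)(C)C`, 800 nM

Compound 3 gives the lowest of the three numbers in this assay, but its steps to both others, a 2.0-fold lower number from compound 1 to compound 3 (0.30 log units; within the scatter) and a 1.5-fold lower number from compound 2 to compound 3 (0.18 log units; within the scatter), lie within the scatter, so the three compounds stand at one level. Compound 4 `COc1cc2ncnc(-n3nc(-c4ccccn4)nc3N)c2cc1OCCNC(=O)OC(C)(C)C` differs from compound 3 by (tert-butoxycarbonyl)amino in place of 2-((tert-butoxycarbonyl)amino)ethyl on a saturated chain carbon, two bonds along the chain from an oxygen on an aromatic ring. The measured steps that alter this same side chain, a 1.3-fold lower number from compound 1 to compound 2 (0.12 log units; within the scatter) and a 2.0-fold lower number from compound 1 to compound 3 (0.30 log units; within the scatter), both stayed within the scatter, so no step beyond the scatter is expected in this assay for this change either. The step expected is a 1.1-fold higher number from compound 3 to compound 4 (0.05 log units; within the scatter). Compound 4 is therefore estimated at 900 nM, with a range of 400 nM to 2000 nM.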

Compound 4, half-maximal inhibitory concentration: 800 nM
Beside the measured number, compound 4's estimate is 1.1-fold (0.05 log units) above it; low and high end bracket the measured number.
By their numbers in this assay, from the lowest: compounds 3, 4, 2 and 1 (each within the scatter of the next).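

Cutting the side chain from 4-((tert-butoxycarbonyl)amino)butyl to 2-((tert-butoxycarbonyl)amino)ethyl in this assay gives no change at the digits printed from compound 3 to compound 4 (within the scatter), so this difference in chain length does not separate the two protected amines. Against the other side chains, the shorter chain gives a 1.5-fold lower number from compound 2 to compound 4 (0.18 log units; within the scatter) and a 2.0-fold lower number from compound 1 to compound 4 (0.30 log units; within the scatter), which places compound 4 at the same level as the rest of the series. No evidence is available to account for this flat result.

On these data alone, whether a free primary amine or a carboxylic acid at the chain end would move the number beyond the scatter remains open. So does the effect of a chain longer than 4-((tert-butoxycarbonyl)amino)butyl.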